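A urea in place of a benzyl on the ring amine

The compounds below may be only part of what the source reports. "The series", "measured", "known", "first", "only" and "open" are said of these compounds alone.

Within the data shown here, compound 1 `COc1ccc(-c2cnc3nc(N)nc(N4CCN(Cc5ccccc5F)CC4)c3n2)cc1OC` is the one compound of the three measured here that gives a number: in a functional assay on cells (T-cell, Homo sapiens) for inhibition (on this read-out higher numbers stand for weaker inhibition and lower numbers for stronger inhibition), compound 1 gives 700 nM. Compound 2 `CCOc1nc(N)nc2ncc(-c3ccc(Cl)c(Cl)c3)nc12` is built on a different arrangement of the shared core, and in this assay compound 2 reaches only a limit of the assay, > 10000 nM. Compound 3 `CCOc1nc(N)nc2ncc(-c3ccc(C#N)cc3)nc12` is close in build to compound 2, and in this assay compound 3 likewise gives a limit, > 10000 nM. Among the measured compounds shown here, this leaves (the limit of > 10000 nM in this assay, at which 2 of the 3 values shown sit), so no step between measured compounds can be read, and compound 1 stands alone with its value.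

Compound 4 `COc1ccc(-c2cnc3nc(N)nc(N4CCN(C(=O)Nc5ccc(C)cc5)CC4)c3n2)cc1OC` differs from compound 1 in one place: (4-methylphenyl)carbamoyl in place of 2-fluorobenzyl on an amine nitrogen in a ring. The amine nitrogen in the ring is kept, and only the group on it is exchanged. For the measured compounds named here, no measured pair tells what this exchange does in this assay, so the expectation rests on compound 1 alone and carries a wide range. The step of a 2.1-fold higher number from compound 1 to compound 4 (0.33 log units; beyond the scatter) is expected to be modest, leaning toward weaker inhibition. In this assay compound 4 is estimated at 1500 nM, with a range from 300 nM to 8000 nM.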

Compound 4, half-maximal inhibitory concentration: 0.8 nM
For compound 4 the middle estimate is 1900-fold (3.27 log units) above the measured one; the measured number lies below the stated range.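

The exchange of 2-fluorobenzyl for (4-methylphenyl)carbamoyl gives, in this assay, an 880-fold lower number from compound 1 to compound 4 (2.94 log units; beyond the scatter), so the amine nitrogen in the ring is a place where the read-out answers very strongly to the group attached. Both groups bring one six-membered aromatic ring of carbon only, which means that the step comes with a change in what surrounds that ring: the entering group has a carbonyl, one hydrogen-bond donor and one hydrogen-bond acceptor, while the leaving group has a fluorine and neither donor nor acceptor. Nothing measured among the compounds shown bears on the reason for this step.

Going by these compounds, this one pair changes the link and the substituents on the aromatic ring at once, so it remains open whether the urea or the methyl group carries the step, a question that an unsubstituted phenylcarbamoyl or a 2-fluorophenylcarbamoyl on the same nitrogen would help to settle. Also open, on these data alone, is how an acetyl group, a sulfonyl group or a longer chain between the carbonyl and the aromatic ring would read at this position.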